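The source may report more compounds than this note shows. Statements on the series, on what has been measured and on what is new or still open speak of the compounds shown alone.

Measured in a functional assay on MDA-MB-468 cells (Homo sapiens) for antiproliferative activity, read by MTT assay, with a stated time of 48 h; a lower number here means a stronger inhibitor, a higher number a weaker inhibitor:

Compound 1 `CN(C)CCNc1cc2c(cn1)cc(NC(=O)c1ccc(N)cc1)c(=O)n2C`: 20400 nM
Compound 2 `CN(C)CCNc1cc2c(cn1)cc(NC(=O)c1cc3ccccc3s1)c(=O)n2C`: 3570 nM
Compound 3 `CC(=O)Nc1cc2cnc(NCCN(C)C)cc2n(C)c1=O`: > 100000 nM, which is a limit of the assay and not a number.

Compound 3 thus sits at the limit of > 100000 nM in this assay, at which 1 of the 3 values shown sits, and the steps of an at least 4.9-fold higher number from compound 1 to compound 3 (0.69 log units; beyond the scatter) and an at least 28-fold higher number from compound 2 to compound 3 (1.44 log units; beyond the scatter) both lie beyond the scatter, so compound 3 stands as the weakest of the three. Compound 4 `CN(C)CCNc1cc2c(cn1)cc(NC(=O)c1ccccc1)c(=O)n2C` differs from compound 3 by phenyl in place of methyl on a carbonyl carbon, that is, acetamido becomes benzamido. Both measured steps bear on this change in reverse: replacing methyl on the carbonyl carbon by an aromatic ring lowered the number each time, modestly for one ring and largely for the other. A lowering step of at least modest size is therefore expected, an at least 6.6-fold lower number from compound 3 to compound 4 (0.82 log units; beyond the scatter). Compound 4 is estimated at 15000 nM, in the range 5000 nM to 60000 nM.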

Compound 4, half-maximal inhibitory concentration: 18300 nM
Compound 4: middle estimate off by 1.2-fold (0.09 log units), on the low side; the range from low to high includes it.
By their numbers in this assay, from the lowest: compound 2; then compounds 4 and 1 (each within the scatter of the next). At a limit, above all of these: compound 3.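

A plain phenyl on the carbonyl carbon is enough to bring the compound into a measurable range in this assay (an at least 5.4-fold lower number from compound 3 to compound 4 (0.73 log units; beyond the scatter)). The value of compound 3 in that step is a limit of the assay and not a number: (the limit of > 100000 nM in this assay, at which 1 of the 4 values shown sits). The amino group on the phenyl ring makes no readable difference (a 1.1-fold lower number from compound 1 to compound 4 (0.05 log units; within the scatter)), while the choice of ring does matter, as 1-benzothiophen-2-yl outperforms phenyl (a 5.1-fold higher number from compound 2 to compound 4 (0.71 log units; beyond the scatter)).

Going by these compounds, it stays open whether a saturated ring such as cyclohexyl or a longer carbon chain could replace the aromatic ring. How a carboxylic acid on the phenyl ring would behave is also unknown.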